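The source may report more compounds than this note shows. Statements on the series, on what has been measured and on what is new or still open speak of the compounds shown alone.

Measured so far:
Compound 1 `CCCN(Cc1ccc(OCCn2c(=O)ccn(C)c2=O)c(OC)c1)C(CC(=O)O)c1ccc(Cl)cc1`: 132 nM
Compound 2 `COc1cc(CN(C2CCC2)C(CC(=O)O)c2ccc(Cl)cc2)ccc1OCCn1c(=O)ccn(C)c1=O`: 152 nM

In an assay on CHO cells for displacement of a labelled ligand from C-X-C chemokine receptor type 3 (Homo sapiens), with a stated time of 60 min (a higher number here means a weaker inhibitor, a lower number a stronger inhibitor), compound 2 gives 152 nM, and the step of a 1.2-fold higher number from compound 1 to compound 2 (0.06 log units; within the scatter) shows that compound 1 and compound 2 sit within the scatter of each other. Compound 3 `CCCCN(Cc1ccc(OCCn2c(=O)ccn(C)c2=O)c(OC)c1)C(CC(=O)O)c1ccc(Cl)cc1` carries butyl in place of cyclobutyl on an amine nitrogen. For the measured compounds named here, the one step measured at this nitrogen, a 1.2-fold higher number from compound 1 to compound 2 (0.06 log units; within the scatter), exchanged a chain for a ring of the same size and moved nothing beyond the scatter, so the step back to a chain is expected to do the same: a 1.1-fold lower number from compound 2 to compound 3 (0.04 log units; within the scatter). Compound 3 is therefore estimated at 140 nM, between 70 nM and 280 nM.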

Compound 3, half-maximal inhibitory concentration in the C-X-C chemokine receptor type 3 assay: 69 nM
For compound 3 the middle estimate is 2.0-fold (0.31 log units) above the measured one; measured number outside the range, below it.
By their numbers in the C-X-C chemokine receptor type 3 assay, from the lowest: compounds 3, 1 and 2 (each within the scatter of the next, the first and the last beyond it).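

On this amine nitrogen, ring and chain are not interchangeable in the C-X-C chemokine receptor type 3 assay: with 4 heavy atoms in each group, butyl in place of cyclobutyl gives a 2.2-fold lower number from compound 2 to compound 3 (0.34 log units; beyond the scatter), a modest step, whereas cyclobutyl in place of propyl gives a 1.2-fold higher number from compound 1 to compound 2 (0.06 log units; within the scatter). Adding a methyl to the end of the propyl chain gives in the C-X-C chemokine receptor type 3 assay a 1.9-fold lower number from compound 1 to compound 3 (0.28 log units; within the scatter), so propyl and butyl cannot be told apart here. The same ring-to-chain change gives in a physicochemical assay for solubility, at pH 1.1 (on this read-out lower numbers stand for lower solubility and higher numbers for higher solubility), no change at the digits printed from compound 2 to compound 3 (within the scatter). In the physicochemical assay compound 2 gives 3000000 nM and compound 3 gives 3000000 nM.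

Going by these compounds, whether a longer chain such as pentyl would continue this trend remains open. The data shown offer no explanation for the gap between ring and chain.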